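A few compounds are considered here, and "the series" means these few. Any claim that something is new, unique, unknown or untested is made for them only; others in the source may bear on it.

Working notes on the series. The shared core is held constant across compounds 1 to 3 and varied only at the tail on the phenyl ring. Compound 1 `CCCC[S+]([O-])c1sc2nc(-c3nccs3)cc(-c3ccc(CN)cc3)c2c1N` gives 11.5 nM in an assay for inhibition of 15-hydroxyprostaglandin dehydrogenase [NAD(+)] (Homo sapiens), read by fluorescence, with a stated time of 15 min, in the presence of a further agent that is not named here; on this read-out lower numbers stand for stronger inhibition and higher numbers for weaker inhibition. Compound 2 `CCCC[S+]([O-])c1sc2nc(-c3nccs3)cc(-c3ccc(CNS(C)(=O)=O)cc3)c2c1N` gives 4.6 nM, and compound 3 `CCCC[S+]([O-])c1sc2nc(-c3nccs3)cc(-c3ccc(COC(=O)CN(C)C)cc3)c2c1N` gives 3.5 nM. Compound 3 carries the lowest number of the three: the step of a 3.3-fold lower number from compound 1 to compound 3 (0.52 log units; beyond the scatter) lies beyond the scatter, while the step of a 1.3-fold lower number from compound 2 to compound 3 (0.12 log units; within the scatter) does not, so compounds 2 and 3 are not separated on this read-out.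

Compound 4 `CCCC[S+]([O-])c1sc2nc(-c3nccs3)cc(-c3ccc(COC(=O)NCC)cc3)c2c1N` is the next step from compound 3: ethylamino in place of (dimethylamino)methyl on a carbonyl carbon. Among the measured compounds shown here, no measured step touches the carbonyl carbon itself; the steps that bear on this region are a 2.5-fold lower number from compound 1 to compound 2 (0.40 log units; beyond the scatter) and a 3.3-fold lower number from compound 1 to compound 3 (0.52 log units; beyond the scatter), both modest, and a 1.3-fold lower number from compound 2 to compound 3 (0.12 log units; within the scatter), within the scatter, showing that this tail accepts several groups with little movement. The expectation is therefore a small step, a 1.4-fold higher number from compound 3 to compound 4 (0.15 log units; within the scatter), if any beyond the scatter. Compound 4 is estimated at 5 nM, with a range from 2 nM to 12 nM.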

Compound 4, half-maximal inhibitory concentration: 3.4 nM
The estimate for compound 4 lay 1.5-fold (0.17 log units) above the measured number, and the stated range covers the measured number.
By their numbers in this assay, from the lowest: compounds 4, 3 and 2 (each within the scatter of the next); then compound 1.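

In this assay, among the compounds shown here, the swap of (dimethylamino)methyl for ethylamino on the carbonyl carbon (a 1.0-fold lower number from compound 3 to compound 4 (0.01 log units; within the scatter)) is the first measured change at this carbonyl carbon, and it leaves the two tails unseparated even though a hydrogen-bond donor enters and a hydrogen-bond acceptor leaves. The (ethylcarbamoyl)oxy tail also stays unseparated from methanesulfonamido (a 1.4-fold lower number from compound 2 to compound 4 (0.13 log units; within the scatter)) and keeps the gap to amino (a 3.4-fold lower number from compound 1 to compound 4 (0.53 log units; beyond the scatter)), so among the four compounds only the amino tail of compound 1 stands apart. No measurement shown here bears on why these tails are not separated.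

Going by these compounds, whether a longer chain such as butylamino, a dimethylamino group or a carboxylic acid on the same carbonyl carbon would stay with compounds 2, 3 and 4 remains open. Also open, on these data alone, is whether the hydrogen on the ethylamino nitrogen matters at all in this assay.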